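Swapping benzoyl for phenylsulfonyl on the ring nitrogen

A few compounds are considered here, and "the series" means these few. Any claim that something is new, unique, unknown or untested is made for them only; others in the source may bear on it.

The two measured compounds share one core and differ only in what sits on an aromatic nitrogen. Compound 1 `CC1=Nc2cc(=O)[nH]n2C(c2cccc([N+](=O)[O-])c2)/C1=C(/O)OC(C)C` carries a hydrogen there; in a functional assay (thoracic aorta) with Oryctolagus cuniculus as the target (on this read-out lower numbers stand for stronger inhibition and higher numbers for weaker inhibition), compound 1 gives 318 nM. Compound 2 `CC1=Nc2cc(=O)n(C(=O)c3ccccc3)n2C(c2cccc([N+](=O)[O-])c2)/C1=C(/O)OC(C)C` carries benzoyl in its place; in this assay compound 2 gives 54 nM, the lower of the two numbers, and the step of a 5.9-fold lower number from compound 1 to compound 2 (0.77 log units; beyond the scatter) lies beyond the scatter. Compound 3 `CC1=Nc2cc(=O)n(S(=O)(=O)c3ccccc3)n2C(c2cccc([N+](=O)[O-])c2)/C1=C(/O)OC(C)C` has not been measured; it differs from compound 2 by phenylsulfonyl in place of benzoyl on an aromatic nitrogen. Among the measured compounds shown here, no measured step compares two different groups on this nitrogen. For the measured compounds named here, the only step touching the place, a 5.9-fold lower number from compound 1 to compound 2 (0.77 log units; beyond the scatter), shows that a group carrying a phenyl ring on that nitrogen went with a clearly lower number than hydrogen did. Phenylsulfonyl keeps a phenyl ring on the same nitrogen, so a number close to that of compound 2 is expected. The step expected is a 1.2-fold higher number from compound 2 to compound 3 (0.08 log units; within the scatter), small enough that either direction would not surprise. Compound 3 is therefore estimated at 65 nM, within 20 nM to 220 nM.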

Compound 3, half-maximal inhibitory concentration: 10 nM
Compound 3: the middle estimate sits 6.5-fold (0.81 log units) above what was measured; the whole stated range lies above it.
By their numbers in this assay, from the lowest: compound 3; then compound 2; then compound 1.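

Among the compounds shown here, until now the only comparison at this nitrogen was hydrogen against benzoyl, so a phenyl ring on that nitrogen could have seemed enough to account for the drop. The new result rules that reading out: in this assay the swap gives a 5.4-fold lower number from compound 2 to compound 3 (0.73 log units; beyond the scatter) even though both groups carry the same six-membered aromatic ring, so what joins that ring to the nitrogen matters as well. Across the three compounds the numbers fall in the order hydrogen, benzoyl, phenylsulfonyl, and the whole span is a 32-fold lower number from compound 1 to compound 3 (1.50 log units; beyond the scatter), which makes this nitrogen a place where a single change moves the number a long way; no measurement here explains why the sulfonyl-linked group gives the lowest number.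

On these data alone, three groups cannot show whether the phenyl ring is needed at all, so it remains open whether methylsulfonyl or acetyl, which keep the link but lose the ring, would stay near the lower numbers. As far as these compounds go, it is also open whether benzyl, with a single carbon as the link, would fall closer to hydrogen or to the two groups that carry a carbonyl or sulfonyl link.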